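From Trifluoromethyl to Chloro on a Shared Core

The source may report more compounds than this note shows. Statements on the series, on what has been measured and on what is new or still open speak of the compounds shown alone.

Measured so far:
compound 1 `CC1(Cc2ccccc2)C(=O)N(c2ccccc2)c2ncccc21` gives 9%
compound 2 `CC1(C)C(=O)N(c2ccc(Cl)c(Cl)c2)c2ncccc21` gives 26%
compound 3 `CC1(C)C(=O)N(c2cccc(C(F)(F)F)c2)c2ncccc21` gives 35%

In a functional assay on the whole organism (Pleural cavity) for inhibition, with Rattus norvegicus as the target, at a dose of 25 mg/kg (on this read-out higher numbers stand for more inhibition at the one dose given (going by the name of the read-out) and lower numbers for less inhibition), compound 3 shows the highest of the three numbers; compound 2 lies within the scatter of it, while compound 1 sits beyond the scatter below it. Compound 4 `CC1(C)C(=O)N(c2cccc(Cl)c2)c2ncccc21` differs from compound 3 in one place: chloro in place of trifluoromethyl on an aromatic carbon. Among the compounds with values here, no pair of measured compounds differing in a single place is available, so the expectation rests on the three values and the change alone. A small downward step is expected, a number 7 percentage points lower from compound 3 to compound 4 (within the scatter), not clearly beyond the scatter. Compound 4 is estimated at 28%, within a range from 12% to 44%.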

Compound 4, a percentage reported as inhibition, in the whole organism at one dose (the size of the read-out at that dose, not a potency): 51%
For compound 4 the middle estimate is 23 percentage points below the measured one; measured number above the stated range.
By their numbers in this assay, from the lowest: compound 1; then compounds 2 and 3 (each within the scatter of the next); then compound 4.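

In this assay, the first single-place comparisons show that this aromatic ring is sensitive to substitution: chloro in place of trifluoromethyl gives a number 16 percentage points higher from compound 3 to compound 4 (beyond the scatter), and hydrogen in place of one chloro gives a number 25 percentage points higher from compound 2 to compound 4 (beyond the scatter). Both steps lie beyond the scatter, so compound 4 stands above each of its two single-change neighbours. Nothing available explains either step. From the compounds shown here alone, whether an amine or a methoxy group at this place would hold or raise the number remains open. So does whether the chloro step carries over to the core of compound 1.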